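Methyl for Chloro on a Cytotoxicity-Limited Scaffold

This account rests on a few compounds, and the source may have more. Where it says the series, first, only, none or still open, it means among the compounds named here.

Going by the values given here, compound 1 `FC(F)(F)c1ccc(NCc2cn(-c3ccccc3)nc2-c2ccc(Br)cc2)cc1` and compound 2 `Clc1ccc(NCc2cn(-c3ccccc3)nc2-c2ccc(Cl)cc2)cc1` share one core but differ in two places, so no single counted step connects them. In an ADME assay on MDBK cells (Bos taurus) for cytotoxicity, read by MTT assay, with a stated time of 72 h (a lower number here means that less compound is tolerated, a higher number that more compound is tolerated), compound 1 gives 46000 nM. Compound 2, in this assay, reaches only the limit of the measurement, > 100000 nM, and no number beyond it. That the limit of > 100000 nM in this assay, at which 1 of the 2 values shown sits, is the whole of what is known of compound 2 here: more of it is tolerated than the assay can report. Compound 3 `Cc1ccc(NCc2cn(-c3ccccc3)nc2-c2ccc(Cl)cc2)cc1` is the next step away from compound 2: methyl in place of chloro on an aromatic carbon. One chlorine leaves and one carbon enters on the same aromatic carbon, with no change in hydrogen-bond donors, acceptors or charge. Among the compounds with values here, no measured step shows how such a swap moves this read-out. With compound 2 already at the limit, the step from compound 2 to compound 3 is expected to be a number no higher from compound 2 to compound 3 (the limit leaves the size open), nothing beyond the scatter in either direction. The estimate for compound 3 in this assay is 100000 nM, expected to lie between 40000 nM and 250000 nM, most likely again as a limit.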

Compound 3, half-maximal cytotoxic concentration: > 100000 nM
Compound 3 ended at the assay's limit; the forecaster's own chance of this, stated with the estimate: 60%; the middle value sits exactly at the limit.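

No step from compound 2 to compound 3 can be read, because the two compounds stand at the same limit of the measurement, which is not a number: the limit of > 100000 nM in this assay, at which 2 of the 3 values shown sit.

The compounds shown leave open how much of compound 2 or compound 3 is actually tolerated in this assay, and whether methyl in place of chloro on an aromatic carbon moves this read-out at all.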